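The compounds below may be only part of what the source reports. "The series", "measured", "known", "first", "only" and "open" are said of these compounds alone.

Measured so far in a functional assay on A549 cells (Homo sapiens) for cytotoxicity, read by MTT assay, with a stated time of 72 h; on this read-out lower numbers stand for stronger inhibition and higher numbers for weaker inhibition:
- compound 1 `O=C(CN1CCN(c2nnc(Cc3ccncc3)c3ccccc23)CC1)Nc1cccc(F)c1`: 4600 nM
- compound 2 `O=C(CN1CCN(c2nnc(Cc3ccccc3)c3ccccc23)CC1)Nc1ccc(F)c(F)c1`: 10100 nM
- compound 3 `Cc1ccccc1NC(=O)CN1CCN(c2nnc(Cc3ccccc3)c3ccccc23)CC1`: "not active" (no number reported)

Compound 1 has the lowest number of the two reported; compound 2 stands beyond the scatter above it, and compound 3 gives no number at all. Compound 4 `O=C(CN1CCN(c2nnc(Cc3ccncc3)c3ccccc23)CC1)Nc1cc(C(F)(F)F)ccc1Cl` differs from compound 1 by 2-chloro-5-(trifluoromethyl)phenyl in place of 3-fluorophenyl on an amide-type nitrogen. For the measured compounds named here, no measured pair shows this change, so the step is open. Given that compound 3 carries a substituted amide aryl and is reported inactive, a weakening is expected rather than a gain, though the step from compound 1 to compound 4 could also fall within the scatter. Compound 4 is therefore estimated at 11000 nM, within 3500 nM to 40000 nM, a step of a 2.4-fold higher number from compound 1 to compound 4 (0.38 log units; beyond the scatter) in this assay.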

Compound 4, half-maximal inhibitory concentration: 1850 nM
Estimate against measurement, compound 4: 5.9-fold (0.77 log units) above; the whole stated range lies above it.
By their numbers in this assay, from the lowest: compound 4; then compound 1; then compound 2.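

In this assay the aryl group on the amide-type nitrogen proves open to change: 2-chloro-5-(trifluoromethyl)phenyl in place of 3-fluorophenyl gives a modest gain (a 2.5-fold lower number from compound 1 to compound 4 (0.40 log units; beyond the scatter)). This single comparison shows that a heavier halogen-bearing aryl group can be carried at this position without loss of activity. No available evidence accounts for the step.

The compounds shown do not separate the contribution of the chlorine from that of the trifluoromethyl group. From the compounds shown here alone, how an amine or a carboxylic acid on this aryl ring would read remains open.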